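Trimming one cyclopropyl ring from a dialkylamino side chain

The source may report more compounds than this note shows. Statements on the series, on what has been measured and on what is new or still open speak of the compounds shown alone.

The measured compounds and their numbers in an assay on IMR-32 cells for displacement of a labelled ligand from corticotropin-releasing factor receptor 1 (Homo sapiens), read by scintillation counting, with a stated time of 2 h; a higher number here means a weaker inhibitor, a lower number a stronger inhibitor:
compound 1 `CCc1nc(N(CC2CC2)CC2CC2)c(CC)nc1-c1ccc(Cl)cc1Cl` gives 26 nM;
compound 2 `CCc1nc(-c2ccc(OC(C)C)cc2OC)c(CC)nc1NC(CC)CC` gives 4.2 nM;
compound 3 `CCc1nc(-c2ccc(C(F)(F)F)cc2OC)c(CC)nc1NC(CC)CC` gives 5.6 nM.

Compound 1 has the highest number of the three, so it is the weakest binder shown: its number lies beyond the scatter above both compound 3 and compound 2. Compound 4 `CCCN(CC1CC1)c1nc(CC)c(-c2ccc(Cl)cc2Cl)nc1CC` is its close relative, differing only in that (ethyl in place of cyclopropyl on a saturated chain carbon bound to a nitrogen on an aromatic ring); seen one bond further out, bis(cyclopropylmethyl)amino becomes (cyclopropylmethyl)(propyl)amino.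

For the measured compounds named here, only one step between measured compounds is available, a 1.3-fold higher number from compound 2 to compound 3 (0.12 log units; within the scatter), and it concerns a substituent on the aromatic ring, not the amino side chain. Going by the values given here, no measured step touches the part of the molecule that changes from compound 1 to compound 4, so the data give no direction. The expectation is therefore a step that stays within the scatter, a 1.2-fold higher number from compound 1 to compound 4 (0.06 log units; within the scatter). Compound 4 is expected to give about 30 nM in this assay, with a likely range from 10 nM to 90 nM.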

Compound 4, inhibition constant: 19.2 nM
Compound 4: middle estimate off by 1.6-fold (0.19 log units), on the high side; measured number inside the range.
By their numbers in this assay, from the lowest: compounds 2 and 3 (each within the scatter of the next); then compounds 4 and 1 (each within the scatter of the next).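

In this assay, replacing cyclopropyl with ethyl on a saturated chain carbon bound to a nitrogen on an aromatic ring gives a 1.4-fold lower number from compound 1 to compound 4 (0.13 log units; within the scatter), so this change cannot be told apart from repeat-to-repeat variation. For the compounds shown here, this is the first direct reading of the amino side chain: with the dichlorophenyl-bearing core of compound 1 held constant, bis(cyclopropylmethyl)amino can become (cyclopropylmethyl)(propyl)amino, losing one ring, without a clear shift in binding. No supporting measurement is available to explain this result.

As far as these compounds go, it remains open whether binding would also hold with both rings opened, as in a dipropylamino group, or with a longer chain such as butyl. The effect of placing a hydroxyl group or an amine at the end of the chain is also unknown.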